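A Methoxy Added to the Benzylsulfanyl Arm

The compounds below may be only part of what the source reports. "The series", "measured", "known", "first", "only" and "open" are said of these compounds alone.

Compound 1 `CC(C(=O)NCc1ccc(C(F)(F)F)cc1N1CCN(c2ccccc2)CC1)c1ccc(NS(C)(=O)=O)c(F)c1` and compound 2 `CC(C(=O)NCc1ccc(C(F)(F)F)cc1SCc1ccccc1)c1ccc(NS(C)(=O)=O)c(F)c1` share one core and differ at a single aromatic carbon. In an assay on CHO cells for antagonist activity at transient receptor potential cation channel subfamily V member 1 (Homo sapiens), read by FLIPR (on this read-out higher numbers stand for weaker inhibition and lower numbers for stronger inhibition), compound 1 gives 2 nM, while compound 2 gives 0.5 nM. Going by the values given here, the step of a 4.0-fold lower number from compound 1 to compound 2 (0.60 log units; beyond the scatter) places compound 2 at the lowest of the two numbers; its only neighbour is compound 1, and that gap is beyond the scatter.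

Compound 3 `COc1ccc(CSc2cc(C(F)(F)F)ccc2CNC(=O)C(C)c2ccc(NS(C)(=O)=O)c(F)c2)cc1` carries the change (methoxy in place of hydrogen on an aromatic carbon). Among the compounds with values here, no measured step bears directly on this change: the single step on record, a 4.0-fold lower number from compound 1 to compound 2 (0.60 log units; beyond the scatter), swapped one whole group on the aromatic carbon for another and tells nothing about a methoxy put onto the ring of the benzylsulfanyl group. Within the data shown here, with no comparable step available, the analyst expects a movement in this assay of no more than the scatter, in either direction, no change at the digits printed from compound 2 to compound 3 (within the scatter). The estimate for compound 3 in this assay is therefore 0.5 nM, with a range from 0.15 nM to 1.6 nM.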

Compound 3, inhibition constant: 2.3 nM
Estimate against measurement, compound 3: 4.6-fold (0.66 log units) below; the measured number lies above the stated range.
By their numbers in this assay, from the lowest: compound 2; then compounds 1 and 3 (each within the scatter of the next).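

The aromatic carbon para to a large group, on the ring of the benzylsulfanyl arm, proves sensitive to substitution: in this assay, methoxy in place of hydrogen there gives a 4.6-fold higher number from compound 2 to compound 3 (0.66 log units; beyond the scatter), so a single added group is enough to move the number beyond the scatter. The advantage of benzylsulfanyl over 4-phenylpiperazin-1-yl does not survive this addition, since (4-methoxybenzyl)sulfanyl in place of 4-phenylpiperazin-1-yl gives a 1.2-fold higher number from compound 1 to compound 3 (0.06 log units; within the scatter), which leaves those two groups indistinguishable on this read-out. Nothing at hand accounts for the shift that methoxy brings.

As far as these compounds go, whether this shift belongs to methoxy in particular or would follow any group on that carbon remains open, and a fluorine, a methyl or a hydroxyl at the same place would separate those two readings, as would a methoxy on another carbon of the same ring. From the compounds shown here alone, it is also open whether the response of this ring depends on the sulfur that links it to the core, a question that a benzyloxy arm carrying the same methoxy would address.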